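The source may report more compounds than this note shows. Statements on the series, on what has been measured and on what is new or still open speak of the compounds shown alone.

Measured compounds:
compound 1 `COc1nc(N)nc2c1c(-c1cc3ccccc3o1)cn2[C@@H]1O[C@H](CO)[C@@H](O)[C@H]1O` gives > 20000 nM
compound 2 `C#Cc1cn([C@@H]2O[C@H](CO)[C@@H](O)[C@H]2O)c2ncnc(OC)c12` gives 190 nM
compound 3 `COc1ncnc2c1c(-c1ccoc1)cn2[C@@H]1O[C@H](CO)[C@@H](O)[C@H]1O` gives 150 nM

Of the compounds shown here, three have been tested in a functional assay on HL-60 cells (Homo sapiens) for antiproliferative activity, read by XTT assay, with a stated time of 72 h; on this read-out higher numbers stand for weaker inhibition and lower numbers for stronger inhibition. For compound 1 the result is only a limit of the assay, > 20000 nM, not a number. Compound 2 gives 190 nM and compound 3 gives 150 nM, so compound 2 holds the higher of the two numbers that are not limits, but the step of a 1.3-fold lower number from compound 2 to compound 3 (0.10 log units; within the scatter) is within the scatter, and the two compounds cannot be told apart on these data.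

Compound 4 `C#Cc1cn([C@@H]2O[C@H](CO)[C@@H](O)[C@H]2O)c2nc(N)nc(OC)c12` has not yet been measured. It differs from compound 2 in one place: amino in place of hydrogen on an aromatic carbon. For the measured compounds named here, no measured step touches this position. Going by the values given here, the only measured step, a 1.3-fold lower number from compound 2 to compound 3 (0.10 log units; within the scatter), swaps the group on a different carbon and gives no guide to an added amino. Among the compounds with values here, compound 1 is the one measured compound carrying an amino at this position, and it sits at the limit of > 20000 nM in this assay, at which 1 of the 3 values shown sits, but it also carries a different group elsewhere, so the two changes cannot be separated.

Compound 4 is therefore expected to give a higher number, with the step of a 16-fold higher number from compound 2 to compound 4 (1.20 log units; beyond the scatter) expected, though with great uncertainty. Compound 4 is estimated at 3000 nM, within a range from 300 nM to 20000 nM.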

Compound 4, half-maximal inhibitory concentration: > 20000 nM
Compound 4 was reported as a limit; the forecaster's own chance of this, stated with the estimate: 30%; at least 6.6-fold (0.82 log units) between middle value and limit.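

In this assay, amino in place of hydrogen on the aromatic carbon between two ring nitrogen atoms gives an at least 100-fold higher number from compound 2 to compound 4 (2.02 log units; beyond the scatter), a large loss of activity. Nothing else differs in this pair, so the loss can be assigned to this single change, which compound 1 could not show, as it also carries 1-benzofuran-2-yl in place of ethynyl. The two compounds with this amino, compound 1 and compound 4, now share one result, which is a limit of the assay and not a number: the limit of > 20000 nM in this assay, at which 2 of the 4 values shown sit.

From the compounds shown here alone, the step from compound 1 to compound 4 cannot be read, as both values are limits, so how much activity remains in either compound and whether the group on the other carbon still matters once the amino is present stay open. Going by these compounds, it also stays open whether this carbon rejects only the amino or any added group, a question that a methyl group, a chlorine atom or a methylamino group on the same carbon of compound 2 would address.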